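Shared core series: three limits and one chloro-for-methoxy step

The compounds below may be only part of what the source reports. "The series", "measured", "known", "first", "only" and "open" are said of these compounds alone.

Three compounds of the series have been run in a functional assay on NCI-H460 cells (Homo sapiens) for antiproliferative activity, read by MTT assay, with a stated time of 24 h; on this read-out higher numbers stand for weaker inhibition and lower numbers for stronger inhibition. Compound 1 `CC(=O)OCCc1c(C)[nH]c(=O)[nH]c1=O` gives > 100000 nM in this assay, which is a limit of the assay rather than a number. Compound 2 `CC(=O)OCCc1c(C)nc(Cl)nc1Cl` likewise gives > 100000 nM in this assay, again a limit. Compound 3 `COc1nc(C)c(CCO)c(OC)n1` gives > 100000 nM in this assay, also a limit. Where compound 3 stands is therefore known only as a limit, and the two other values shown are limits as well; the whole of the evidence amounts to the limit of > 100000 nM in this assay, at which 3 of the 3 values shown sit. Among the compounds with values here, no pair of measured compounds differs in one place, so no measured step is available.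

Compound 4 `COc1nc(Cl)nc(C)c1CCO` has not yet been measured in this assay. It differs from compound 3 in one place: chloro in place of methoxy on an aromatic carbon. With every measured value sitting at the limit, no direction can be read from the series for this change. No step beyond the usual scatter is expected in either direction, and the most likely outcome for compound 4 is another limit. The step this expectation means is a number no higher from compound 3 to compound 4 (the limit leaves the size open). Compound 4 is estimated at 100000 nM in this assay, with a range from 30000 nM to 300000 nM.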

Compound 4, half-maximal inhibitory concentration: > 100000 nM
Compound 4: no number, only a limit (the forecaster's own chance of this, stated with the estimate: 85%); the middle value sits exactly at the limit.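

In this assay compound 4 gives > 100000 nM as a limit of the assay and not a number. Within the data shown here, compound 3 also stands at a limit, so no step between compound 3 and compound 4 can be read. The compounds shown leave open whether any change on the shared core gives a readable number in this assay at all.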